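Swapping halogens on the aniline ring of a quinoline series

The source may report more compounds than this note shows. Statements on the series, on what has been measured and on what is new or still open speak of the compounds shown alone.

Compound 2 `CN1CCN(CCCOc2cccc3nc(Nc4ccc(F)c(F)c4)ccc23)CC1` gives 2600 nM in a functional assay on cells (Panel leukemia (Carcinoma cell lines), Homo sapiens) for inhibition, read by sulforhodamine B assay, with a stated time of 48 h (a lower number here means a stronger inhibitor of growth, a higher number a weaker inhibitor of growth), the lower of the two numbers seen so far, and compound 1 `CC(C)c1ccc(Nc2ccc3c(OCCCN4CCN(C)CC4)cccc3n2)cc1` gives 4240 nM. For the measured compounds named here, the only measured step, a 1.6-fold lower number from compound 1 to compound 2 (0.21 log units; within the scatter), changed the same aryl ring and stayed within the scatter. Compound 3 `CN1CCN(CCCOc2cccc3nc(Nc4cc(Cl)cc(Cl)c4)ccc23)CC1` differs from compound 2 by 3,5-dichlorophenyl in place of 3,4-difluorophenyl on a nitrogen on an aromatic ring. Going by the values given here, since the one comparable change moved little, compound 3 is expected to show no shift beyond the scatter, an estimated step of no change at the digits printed from compound 2 to compound 3 (within the scatter). Compound 3 is therefore estimated at 2600 nM, within a range from 900 nM to 7500 nM.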

Compound 3, concentration for 50% growth inhibition: 1800 nM
Compound 3: the middle estimate sits 1.4-fold (0.16 log units) above what was measured; low and high end bracket the measured number.
By their numbers in this assay, from the lowest: compounds 3, 2 and 1 (each within the scatter of the next, the first and the last beyond it).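

In this assay, changing the aryl group on this nitrogen can move the number beyond the scatter, as a 2.4-fold lower number from compound 1 to compound 3 (0.37 log units; beyond the scatter) shows with 3,5-dichlorophenyl in place of 4-isopropylphenyl. Replacing 3,4-difluorophenyl with 3,5-dichlorophenyl gives only a 1.4-fold lower number from compound 2 to compound 3 (0.16 log units; within the scatter), and this single change alters both the halogen and the numbers in the group's name, so neither can be judged alone. No measurement here gives a reason for either step. Still open, on these data alone, is how 3,4-dichlorophenyl or 3,5-difluorophenyl would compare, which could separate those two changes, and whether a methoxy or nitrile group on the ring would fit the same picture.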